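This account rests on a few compounds, and the source may have more. Where it says the series, first, only, none or still open, it means among the compounds named here.

Compound 1, `CCN1C(=O)C(O)(Cc2nnn[nH]2)c2ccccc21`: in a functional assay on PC-3 cells (Homo sapiens) for antiproliferative activity, read by MTT assay, with a stated time of 48 h (on this read-out lower numbers stand for stronger inhibition and higher numbers for weaker inhibition), compound 1 gives > 100000 nM, which is a limit of the assay and not a number.
Compound 2, `CCN1C(=O)C(O)(Cc2nnn[nH]2)c2cc(Cl)ccc21`: in this assay compound 2 gives 79300 nM.
Compound 3, `O=C1N(Cc2ccc(Br)cc2)c2ccc(Cl)cc2C1(O)Cc1nnn[nH]1`: in this assay compound 3 gives 87900 nM.

Of the two numbers shown, compound 3 and compound 2 sit within the scatter of each other, the step being a 1.1-fold higher number from compound 2 to compound 3 (0.04 log units; within the scatter); the only other value, that of compound 1, is a limit (the limit of > 100000 nM in this assay, at which 1 of the 3 values shown sits).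

Compound 4 is `O=C1N(Cc2ccc(Br)cc2)c2ccc(Br)cc2C1(O)Cc1nnn[nH]1`. It differs from compound 3 in one place: bromo in place of chloro on an aromatic carbon. Of the measured steps, the one that touches the same aromatic carbon is an at least 1.2-fold lower number from compound 1 to compound 2 (0.10 log units; that floor lies within the scatter), where a halogen entered for hydrogen; the other, a 1.1-fold higher number from compound 2 to compound 3 (0.04 log units; within the scatter), concerns the group on the ring nitrogen and bears little on a swap of one halogen for another. Neither measured step reached beyond the scatter, and the exchange of chloro for bromo is a smaller change than either. The expectation for compound 4 in this assay is therefore a step of a 1.0-fold lower number from compound 3 to compound 4 (0.01 log units; within the scatter), that is, no movement beyond the scatter, in either direction. Compound 4 is thus estimated at 85000 nM, with a range from 35000 nM to 200000 nM.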

Compound 4, half-maximal inhibitory concentration: > 100000 nM
Compound 4 ended at the assay's limit; the forecaster's own chance of this, stated with the estimate: 35%; middle value at least 1.1-fold (0.07 log units) away from the limit.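

In this assay, within the data shown here, the exchange of chloro for bromo gives an at least 1.1-fold higher number from compound 3 to compound 4 (0.05 log units; that floor lies within the scatter), and this is the first step in which one halogen replaces another on this aromatic carbon, rather than a halogen replacing hydrogen. On these data alone, with the heavier halogen in place and the 4-bromophenyl group kept on the ring nitrogen, the step cannot be told apart from the scatter, although its true size stays unknown. Compound 4 gives > 100000 nM, which is a limit of the assay and not a number, and this places it with compound 1 at the end of what the assay reports: the limit of > 100000 nM in this assay, at which 2 of the 4 values shown sit.

The compounds shown carry only hydrogen, chloro or bromo on this carbon, so they leave open whether an amine, a methoxy group or a carboxylic acid there would produce a step beyond the scatter. They also leave open whether bromo on this carbon behaves in the same way when the group on the ring nitrogen is ethyl or a longer chain.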